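The source may report more compounds than this note shows. Statements on the series, on what has been measured and on what is new or still open speak of the compounds shown alone.

Measured compounds:
- compound 1 `CCc1nc(C)c(CN2CCN(c3cccc4[nH]c(-c5ccc(C(C)(C)C)cc5)nc34)CC2)o1` gives 320 nM
- compound 2 `CCc1nc(C)c(CN2CCN(c3cccc4[nH]c(-c5ccc(C(C)(C)C)cc5)nc34)CC2)s1` gives 120 nM
- compound 3 `CCc1cc(CN2CCN(c3cccc4[nH]c(-c5ccc(C(C)(C)C)cc5)nc34)CC2)nn1C` gives 350 nM

All three were run in an assay on isolated protein for displacement of a labelled ligand from Gonadotropin-releasing hormone receptor (Rattus norvegicus); a lower number here means a stronger inhibitor, a higher number a weaker inhibitor. Compound 2 holds the lowest of the three numbers; its nearest neighbour is compound 1 (a 2.7-fold lower number from compound 1 to compound 2 (0.43 log units; beyond the scatter)), and the step onward to compound 3 is of similar size (a 2.9-fold higher number from compound 2 to compound 3 (0.46 log units; beyond the scatter)). Between compound 1 and compound 3 nothing separates the pair (a 1.1-fold higher number from compound 1 to compound 3 (0.04 log units; within the scatter)).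

Compound 4 `CCc1nc(CN2CCN(c3cccc4[nH]c(-c5ccc(C(C)(C)C)cc5)nc34)CC2)cn1C` is the next member, differing from compound 2 by 2-ethyl-1-methyl-1H-imidazol-4-yl in place of 2-ethyl-4-methyl-1,3-thiazol-5-yl on a saturated chain carbon bound to an amine nitrogen in a ring. The bearing steps are those in which the same five-membered ring is exchanged on the same carbon: from compound 1 to compound 2 and from compound 2 to compound 3, each a modest step beyond the scatter, and both leaving compound 2 as the strongest binder of the set. Among the compounds with values here, an imidazole at this place has no direct precedent here, so the expectation rests on the two ring swaps already seen, both of which moved away from compound 2 upward. Compound 4 is therefore expected to give a modestly higher number, a 2.5-fold higher number from compound 2 to compound 4 (0.40 log units; beyond the scatter), in this assay. The estimate for compound 4 is 300 nM, within a range of 120 nM to 750 nM.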

Compound 4, half-maximal inhibitory concentration: 78 nM
Estimate against measurement, compound 4: 3.8-fold (0.59 log units) above; the measured number lies below the stated range.
By their numbers in this assay, from the lowest: compounds 4 and 2 (each within the scatter of the next); then compounds 1 and 3 (each within the scatter of the next).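

In this assay, 2-ethyl-1-methyl-1H-imidazol-4-yl and 2-ethyl-4-methyl-1,3-thiazol-5-yl cannot be told apart on this saturated chain carbon bound to an amine nitrogen in a ring, with a 1.5-fold lower number from compound 2 to compound 4 (0.19 log units; within the scatter) lying within the scatter. The imidazole does stand clear of the other two rings, with a 4.1-fold lower number from compound 1 to compound 4 (0.61 log units; beyond the scatter) and a 4.5-fold lower number from compound 3 to compound 4 (0.65 log units; beyond the scatter), so a swap of one ethyl- and methyl-bearing five-membered aromatic ring for another can shift binding here or leave it level, depending on the pair. No measurement at hand accounts for these differences.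

Open, going by these compounds, is whether a 1,2,4-triazole ring on the same carbon would stay level with compound 4. Also open, on these data alone, is whether a propyl group or a cyclopropyl group in place of the ethyl of the imidazole would keep that standing.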